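A few compounds are considered here, and "the series" means these few. Any claim that something is new, unique, unknown or untested is made for them only; others in the source may bear on it.

Series notes. The shared core carries a nitrile, and the measured compounds are compound 1 `Cc1ccc(-c2c(C#N)[n+]([O-])c3ccccc3[n+]2[O-])cc1`, compound 2 `Cc1ccc(-c2c(C#N)[n+]([O-])c3cc(C)ccc3[n+]2[O-])cc1` and compound 3 `COc1ccc2c(c1)[n+]([O-])c(C#N)c(-c1ccc(C)cc1)[n+]2[O-]`; compound 4 `COc1ccc(-c2c(C#N)[n+]([O-])c3ccccc3[n+]2[O-])cc1` is not yet measured. In a physicochemical assay for lipophilicity, measured as octanol-water partition (a higher number here means a more lipophilic compound, a lower number a more polar compound), compound 1 gives 2.09, compound 2 gives 2.33 and compound 3 gives 1.83. Compound 2 differs from compound 1 by hydrogen in place of methyl on an aromatic carbon and from compound 3 by methoxy in place of methyl on an aromatic carbon, which gave a number 0.50 log units lower from compound 2 to compound 3 (beyond the scatter). Compound 4 differs from compound 1 by methoxy in place of methyl on an aromatic carbon. The two changes are the same kind of change, not the same: one sits meta to a fused ring and para to a fused ring, the other para to a large group. In this assay, among the compounds with values here, the step expected from compound 1 to compound 4 is a number 0.49 log units lower from compound 1 to compound 4 (beyond the scatter), taken beside the measured one because a number 0.50 log units lower from compound 2 to compound 3 (beyond the scatter) is the only example here. Compound 4 is therefore expected near 1.6, estimated between 1.3 and 1.9.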

Compound 4, partition coefficient: 1.58
Estimate against measurement, compound 4: 0.02 log units above; the measured number falls inside the stated range.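

In this assay, methoxy in place of methyl on an aromatic carbon, para to a large group, gives a number 0.51 log units lower from compound 1 to compound 4 (beyond the scatter), and the same kind of change at the other place gives a number 0.50 log units lower from compound 2 to compound 3 (beyond the scatter), so the step carried over in direction and size in this pair of examples. Two examples do not make a rule for other places or other cores. Nothing given here explains the match.

On these data alone, whether a step of this size would follow with an amine, a carboxylic acid or a longer chain in place of the methyl remains open. So does whether the two changes would add up in a single compound.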